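Cyclopropyl in place of hydrogen on the aromatic carbon

A few compounds are considered here, and "the series" means these few. Any claim that something is new, unique, unknown or untested is made for them only; others in the source may bear on it.

Compound 1 `C[C@H]1[C@H](NCc2cccs2)C[C@H]2C[C@@H]1C2(C)C` is read in an ADME assay on MDCK cells (Canis lupus familiaris) for cytotoxicity, read by microscopy, with a stated time of 48 h (a higher number here means that more compound is tolerated, a lower number that less compound is tolerated), where compound 1 gives 25000 nM. Compound 3 `C[C@H]1[C@H](NCc2cc(-c3ccsc3)cs2)C[C@H]2C[C@@H]1C2(C)C` gives 25000 nM, and the step runs no change at the digits printed from compound 1 to compound 3 (within the scatter). Compound 2 `C[C@H]1[C@H](NCc2ccoc2)C[C@H]2C[C@@H]1C2(C)C` reaches only a limit of the assay, > 100000 nM. That step, an at least 4.0-fold higher number from compound 1 to compound 2 (0.60 log units; beyond the scatter), rests on (the limit of > 100000 nM in this assay, at which 1 of the 3 values shown sits). Compound 1 therefore stands level with compound 3 at the digits shown, with the remaining value a limit.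

Compound 4 `C[C@H]1[C@H](NCc2sccc2C2CC2)C[C@H]2C[C@@H]1C2(C)C` differs from compound 1 by cyclopropyl in place of hydrogen on an aromatic carbon. The step that bears on it is the substitution on an aromatic carbon giving compound 3, no change at the digits printed from compound 1 to compound 3 (within the scatter); the exchange of thiophen-2-yl for furan-3-yl giving compound 2 concerns a different position. No step beyond the scatter is therefore expected, no change at the digits printed from compound 1 to compound 4 (within the scatter). Compound 4 is estimated at 25000 nM, in the range 10000 nM to 100000 nM.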

Compound 4, minimum cytotoxic concentration: 25000 nM
The estimate for compound 4 equals the measured number at the digits printed, within the range that was stated.
By their numbers in this assay, from the lowest: compounds 1, 3 and 4 (each within the scatter of the next). At a limit, above all of these: compound 2.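

In this assay, cyclopropyl on the aromatic carbon next to the ring atom that bears a large group gives no change at the digits printed from compound 1 to compound 4 (within the scatter). This place, two ring bonds from the ring sulfur, carries a group for the first time among the compounds shown, and a three-membered carbon ring there leaves the reading level with compound 1. Nothing shown gives a cause for this result.

On these data alone, whether an amine or a carboxylic acid at this place would also leave the reading level stays open. So does the effect of a longer chain here.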